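Chloro for methyl on the benzyl group: compound 4

The compounds below may be only part of what the source reports. "The series", "measured", "known", "first", "only" and "open" are said of these compounds alone.

Measured compounds:
compound 1, `CCN1CCN(CC(=O)Nc2ccc(-c3nc(-c4ccccc4)c(-c4ccccc4)n3C)cc2)CC1`, gives 13.9% in a functional assay on HT-29 cells (Homo sapiens) for cytotoxicity, read by MTT assay, with a stated time of 24 h, tested at 1.6 ug/mL; on this read-out lower numbers stand for a weaker effect and higher numbers for a stronger effect at the one concentration tested.
compound 2, `Cn1c(-c2ccc(NC(=O)CN3CCN(Cc4ccccc4)CC3)cc2)nc(-c2ccccc2)c1-c1ccccc1`, gives 26% in this assay.
compound 3, `Cc1ccc(CN2CCN(CC(=O)Nc3ccc(-c4nc(-c5ccccc5)c(-c5ccccc5)n4C)cc3)CC2)cc1`, gives 26.4% in this assay.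

Compound 3 has the highest of the three numbers, but it is not separated from compound 2: a number 0.4 percentage points higher from compound 2 to compound 3 (within the scatter). It is separated from compound 1: a number 12.5 percentage points higher from compound 1 to compound 3 (beyond the scatter), matching a number 12.1 percentage points higher from compound 1 to compound 2 (beyond the scatter), so the move from methyl to a benzyl group on the ring amine nitrogen is what lifted the read-out, and the methyl on the aromatic ring of compound 3 added nothing that can be told apart from scatter.

Compound 4, `Cn1c(-c2ccc(NC(=O)CN3CCN(Cc4ccc(Cl)cc4)CC3)cc2)nc(-c2ccccc2)c1-c1ccccc1`, differs from compound 3 in one place: chloro in place of methyl on an aromatic carbon. Among the measured compounds shown here, no measured step involves chloro. For the measured compounds named here, the only step at this position, a number 0.4 percentage points higher from compound 2 to compound 3 (within the scatter), shows that changing the substituent on this aromatic carbon left the number where it was. On that basis the step from compound 3 to compound 4 is expected to stay within the scatter, a number 0.6 percentage points higher from compound 3 to compound 4 (within the scatter), in either direction.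

Compound 4 is therefore estimated at 27% in this assay, with a range from 14% to 40%.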

Compound 4, a percentage reported as activity, at one concentration (the size of the read-out at that concentration, not a potency): 16.4%
The estimate for compound 4 lay 10.6 percentage points above the measured number; low and high end bracket the measured number.
By their numbers in this assay, from the lowest: compounds 1, 4, 2 and 3 (each within the scatter of the next, the first and the last beyond it).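

Chloro on this aromatic carbon gives a number 10 percentage points lower from compound 3 to compound 4 (within the scatter) and a number 9.6 percentage points lower from compound 2 to compound 4 (within the scatter), so compound 4 cannot be told apart from either compound 2 or compound 3, although both steps are much larger than the one earlier step at this carbon, a number 0.4 percentage points higher from compound 2 to compound 3 (within the scatter). With a number 2.5 percentage points higher from compound 1 to compound 4 (within the scatter), compound 4 cannot be told apart from compound 1 either, so the separation that compound 2 and compound 3 show from compound 1 is not shared by the 4-chlorobenzyl group, and compound 4 goes against any reading that every benzyl group on the ring amine nitrogen lifts the number. Nothing measured here accounts for the size of the chloro steps.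

The compounds shown leave open whether methoxy, fluoro or an amine on this aromatic carbon would separate from hydrogen, methyl or chloro in this assay, where all four compounds now lie within reach of compound 4. They also leave open how these compounds would compare across a range of concentrations, since a read-out at one concentration gives no potency.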